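This account rests on a few compounds, and the source may have more. Where it says the series, first, only, none or still open, it means among the compounds named here.

Compound 1 `CC(=O)N1CC2CC(C1)N2` is the smaller of two measured amides. In an assay on SH-EP1 cells for agonist activity at Neuronal acetylcholine receptor; alpha4/beta2 (Homo sapiens), read by FLIPR and calcium flux (a higher number here means a larger maximal response, a lower number a smaller maximal response), compound 1 gives 95%, the lower of the two numbers, while compound 2 `CCCC(=O)N1CC2CC(C1)N2` gives 110%. Going by the values given here, the one measured step, a number 15 percentage points higher from compound 1 to compound 2 (beyond the scatter), lengthens the chain on the carbonyl carbon. Compound 3 `C[C@@H]1C[C@H]1C(=O)N1CC2CC(C1)N2` also grows at that carbon: 2-methylcyclopropyl in place of methyl on a carbonyl carbon. Among the compounds with values here, that one step is the only guide, so a modest rise is expected, though the added ring is not ethyl and this adds uncertainty. For compound 3 the expected value is 105%, between 88% and 122%, a step of a number 10 percentage points higher from compound 1 to compound 3 (within the scatter).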

Compound 3, largest response reached (Emax), in percent of the reference or control that the assay uses: 110%
The estimate for compound 3 lay 5 percentage points below the measured number; low and high end bracket the measured number.
By their numbers in this assay, from the lowest: compound 1; then compounds 2 and 3 (each within the scatter of the next).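

In this assay the change to 2-methylcyclopropyl on the carbonyl carbon gives a number 15 percentage points higher from compound 1 to compound 3 (beyond the scatter) and, set against propyl, no change at the digits printed from compound 2 to compound 3 (within the scatter) at this position. The rise seen with the propyl group of compound 2 thus also appears with a group carrying a three-membered ring, so among these compounds an open chain is not required. Nothing given here explains this result. From the compounds shown here alone, whether a longer chain such as hexyl, a phenyl ring or an amine on this carbon would keep the response remains open. Going by these compounds, the part played by the two defined stereocentres of 2-methylcyclopropyl is also open.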